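The source may report more compounds than this note shows. Statements on the series, on what has been measured and on what is new or still open speak of the compounds shown alone.

Two compounds have been measured so far in a functional assay on MDA-MB-231 cells (Homo sapiens) for antiproliferative activity, read by sulforhodamine B assay, with a stated time of 48 h (a lower number here means a stronger inhibitor, a higher number a weaker inhibitor), as follows:

- Compound 1 (`O=C(NCCCNc1cc(-c2cn(-c3ccccc3)nc2-c2cccc(O)c2)ccn1)Nc1ccc(F)cc1`) gives 2180 nM 
- Compound 2 (`O=C(NCCCNc1cc(-c2cn(-c3ccccc3)nc2-c2cccc(O)c2)ccn1)Nc1cccc(C(F)(F)F)c1`) gives 2850 nM 

Among the compounds with values here, compound 1 has a single neighbour on these numbers, and the two cannot be told apart: the one measured step is a 1.3-fold higher number from compound 1 to compound 2 (0.12 log units; within the scatter) and it puts 3-(trifluoromethyl)phenyl in place of 4-fluorophenyl on an amide-type nitrogen.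

Compound 3 (`COc1cccc(-c2nn(-c3ccccc3)cc2-c2ccnc(NCCCNC(=O)Nc3ccc(F)cc3)c2)c1`) departs from compound 1 in one place: methyl in place of hydrogen on an oxygen on an aromatic ring (hydroxy to methoxy, or 3-hydroxyphenyl to 3-methoxyphenyl). Within the data shown here, the measured step lies elsewhere in the molecule, so it bears on this change only indirectly, and no measured pair tests this oxygen. Among the measured compounds shown here, the only guides are compound 1 at 2180 nM and the small size of that one step. No step beyond the scatter is therefore expected in this assay and there is only a slight lean towards a higher number. The expected step is a 1.4-fold higher number from compound 1 to compound 3 (0.14 log units; within the scatter) in this estimate. Compound 3 is estimated at 3000 nM with an expected range from 1200 nM to 8000 nM in this measurement.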

Compound 3, half-maximal inhibitory concentration: 7840 nM
For compound 3 the middle estimate is 2.6-fold (0.42 log units) below the measured one, and the stated range covers the measured number.
By their numbers in this assay, from the lowest: compounds 1 and 2 (each within the scatter of the next); then compound 3.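

In this assay, the oxygen on the aromatic ring is the only place shown so far where a single change moves the number beyond the scatter: methyl in place of hydrogen, hydroxy to methoxy, gives a 3.6-fold higher number from compound 1 to compound 3 (0.56 log units; beyond the scatter) and so a weaker inhibitor. Within the data shown here, the one earlier step, 3-(trifluoromethyl)phenyl in place of 4-fluorophenyl on an amide-type nitrogen, was a 1.3-fold higher number from compound 1 to compound 2 (0.12 log units; within the scatter) and showed no change that could be read, so this is the first sign that the compounds respond to a change, although the effect is modest and rests on a single pair. Nothing shown here accounts for the weaker result with the methoxy group.

As far as these compounds go, it remains open whether an amine or a carboxylic acid in place of the hydroxy would keep the number of compound 1, and whether an ethoxy group on the same oxygen would raise the number further than methoxy does. From the compounds shown here alone, it is also open whether the same methyl change would give a similar step on compound 2, which carries 3-(trifluoromethyl)phenyl on the amide-type nitrogen.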